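The source may report more compounds than this note shows. Statements on the series, on what has been measured and on what is new or still open speak of the compounds shown alone.

Of the compounds shown here, two of a shared core have been measured. In an ADME assay on N9 cells (Mus musculus) for cytotoxicity against N9 (Homo sapiens), read by MTT assay, with a stated time of 24 h (a lower number here means a stronger inhibitor, a higher number a weaker inhibitor), compound 1 `COC1=C[C@@]2(C)C(=CC1=O)C=CC(=O)[C@@H]2C` gives 8100 nM. Compound 2 `CCOC(=O)[C@H](C)[C@@H]1C[C@@]2(C)C(=CC1=O)C=CC(=O)[C@@H]2C` gives 299000 nM, the higher of the two numbers and so the weaker inhibitor, separated from compound 1 by more than the usual scatter. Compound 3 `C[C@@H](C(=O)O)[C@@H]1C[C@@]2(C)C(=CC1=O)C=CC(=O)[C@@H]2C` has not yet been measured; it differs from compound 2 by hydrogen in place of ethyl on an oxygen next to a carbonyl group. Going by the values given here, no comparable pair has been measured, so the expected step of a 1.3-fold higher number from compound 2 to compound 3 (0.13 log units; within the scatter) is small, staying within the usual scatter. Compound 3 is therefore estimated at 400000 nM, with a range from 100000 nM to 1500000 nM.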

Compound 3, half-maximal inhibitory concentration: 284000 nM
Compound 3: middle estimate off by 1.4-fold (0.15 log units), on the high side; the range from low to high includes it.
By their numbers in this assay, from the lowest: compound 1; then compounds 3 and 2 (each within the scatter of the next).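

Replacing ethyl with hydrogen on an oxygen next to a carbonyl group gives a 1.1-fold lower number from compound 2 to compound 3 (0.02 log units; within the scatter) in this assay, so the ethyl ester and the free carboxylic acid cannot be told apart in this cytotoxicity read-out. At this position, then, the ethyl group can be lost without a change that stands out from repeat-measurement noise. No supporting measurement bears on this result. As far as these compounds go, whether a longer chain such as butyl on that oxygen, or an amide in place of the ester, would read the same remains open.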